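Extending the Acid Chain of Compound 3

The source may report more compounds than this note shows. Statements on the series, on what has been measured and on what is new or still open speak of the compounds shown alone.

- compound 1 `N=C(N)c1ccc(NC(=O)c2ccc3c(c2)NC(CC(=O)O)CCC3)cc1` gives 3900 nM
- compound 2 `N=C(N)c1ccc(NC(=O)c2cccc(NC(CC(=O)O)C(=O)O)c2)cc1` gives 4700 nM
- compound 3 `CN(C(=O)c1ccc2c(c1)CN(CC(=O)O)C(=O)CC2)c1ccc(C(=N)N)cc1` gives only the assay limit > 200000 nM

All three results come from a functional assay (plasma) for inhibition, with Homo sapiens as the target; on this read-out lower numbers stand for stronger inhibition and higher numbers for weaker inhibition. Compound 1 and compound 2 lie within the usual scatter of each other. Compound 3 sits at the limit of > 200000 nM in this assay, at which 1 of the 3 values shown sits, and therefore has a limit of the assay rather than a number.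

Compound 4 `CN(C(=O)c1ccc2c(c1)CN(CCC(=O)O)C(=O)CC2)c1ccc(C(=N)N)cc1` is compound 3 with a single change (carboxymethyl in place of carboxy on a saturated chain carbon bound to an amide-type nitrogen in a ring). This places carboxymethyl in place of carboxy on a saturated chain carbon bound to an amide-type nitrogen in a ring. The same difference can be read as carboxymethyl to 2-carboxyethyl.

Within the data shown here, no measured pair shows this change, so any forecast is uncertain. Compound 1 (3900 nM) and compound 2 (4700 nM) show that measurable inhibition is reachable in this assay, although compound 3 goes against any general trend. A sizeable move towards stronger inhibition is therefore expected, though compound 4 could remain at the limit. The estimated change is an at least 10-fold lower number from compound 3 to compound 4 (1.00 log units; beyond the scatter) in size. For compound 4 the expected value is 20000 nM, with an estimated range from 2000 nM to 200000 nM.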

Compound 4, half-maximal inhibitory concentration: > 200000 nM
Compound 4: a limit, no number (the forecaster's own chance of this, stated with the estimate: 25%); middle value at least 10-fold (1.00 log units) away from the limit.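

In this assay, compound 4 gives > 200000 nM, which is a limit of the assay and not a number, and compound 3 stands at the same limit: the limit of > 200000 nM in this assay, at which 2 of the 4 values shown sit.

Among these compounds, with both compounds at a limit, no step between compound 3 and compound 4 can be read. The compounds shown leave open whether 2-carboxyethyl in place of carboxymethyl changes inhibition at all.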